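A few compounds are considered here, and "the series" means these few. Any claim that something is new, unique, unknown or untested is made for them only; others in the source may bear on it.

Measured compounds:
compound 1, `COc1ccc(C2=NN(c3ccccc3)C(c3ccc(C)cc3)C2S(=O)(=O)CC2=NCCO2)cc1`, in a functional assay, tested at 50 ug/mL; a higher number here means a stronger effect of the compound at the concentration tested, a lower number a weaker effect: 62.5%
compound 2, `COc1ccc(C2=NN(c3ccccc3)C(c3ccc(C)cc3)C2S(=O)(=O)CC2=NCCS2)cc1`, in this assay: 42.6%
compound 3, `O=S(=O)(CC1=NCCS1)c1c(-c2ccccc2)noc1-c1ccccc1`, in this assay: "not active" (no number reported)

Compound 2 and compound 1 share a core and differ in one place. The change is a group of 5 heavy atoms (3 carbon, 1 nitrogen, 1 oxygen; one five-membered non-aromatic ring with 2 hetero atoms) in place of a group of 5 heavy atoms (3 carbon, 1 nitrogen, 1 sulfur; one five-membered non-aromatic ring with 2 hetero atoms), on a saturated chain carbon bound to a sulfonyl sulfur, and it made a step of a number 19.9 percentage points higher from compound 2 to compound 1 (beyond the scatter). Going by the values given here, this is the one measured step in the set, and it is modest but beyond the scatter.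

Compound 3 carries a different core. How its core differs from that of compound 2 is not broken down here. Compound 3 was reported as not active in this assay, with no number given. Among the compounds with values here, compound 4, `O=S(=O)(CC1=NCCO1)c1c(-c2ccccc2)noc1-c1ccccc1`, is not yet measured; it differs from compound 3 by a group of 5 heavy atoms (3 carbon, 1 nitrogen, 1 oxygen; one five-membered non-aromatic ring with 2 hetero atoms) in place of a group of 5 heavy atoms (3 carbon, 1 nitrogen, 1 sulfur; one five-membered non-aromatic ring with 2 hetero atoms), on a saturated chain carbon bound to a sulfonyl sulfur, which is the same change as the one from compound 2 to compound 1, made at the same place.

The expectation for compound 4 rests on a single precedent. On the core of compound 1 and compound 2 the change gave a number 19.9 percentage points higher from compound 2 to compound 1 (beyond the scatter), so on the core of compound 3 a gain of similar size is the natural guess, starting from a compound that showed no activity. Compound 4 is therefore expected to land at about 15% in this assay, with a plausible range from 0% to 40%, and a real chance that it too is reported only as not active.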

Compound 4, a percentage reported as activity, at one concentration (the size of the read-out at that concentration, not a potency): 57.2%
The estimate for compound 4 lay 42.2 percentage points below the measured number, outside the stated range (above it).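

In this assay compound 4 gives 57.2% and compound 3 has no number, which means no new step can be read between compound 3 and compound 4. No measurement shown here accounts for this result. The compounds shown leave open how large the change from compound 3 to compound 4 is as a number, and whether the same exchange behaves alike on other cores.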